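A few compounds are considered here, and "the series" means these few. Any claim that something is new, unique, unknown or untested is made for them only; others in the source may bear on it.

Working notes on the series.

Compound 1 `C/C(=C\c1cc(-c2ccccc2)co1)C(N)=O` is the parent of the first pair. In a functional assay on MCF7 cells (Homo sapiens) for cytotoxicity, read by CCK-8 assay, with a stated time of 24 h (on this read-out lower numbers stand for stronger inhibition and higher numbers for weaker inhibition), compound 1 gives 3340 nM. Compound 2 `C/C(=C\c1cc(-c2ccc(C)cc2)co1)C(N)=O` differs from it in one place: methyl in place of hydrogen on an aromatic carbon. In this assay compound 2 gives 1630 nM, and the step of a 2.0-fold lower number from compound 1 to compound 2 (0.31 log units; beyond the scatter) goes with that methyl in place of hydrogen on an aromatic carbon.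

Compound 3 `C/C(=C\c1cccc(-c2ccccc2)c1)C(N)=O` carries a different core; the difference between the core of compound 3 and the core of compound 1 is not broken down here. In this assay compound 3 gives 6540 nM. Compound 3 and compound 1 sit within the scatter of each other, so no order between them is claimed; against compound 2 the number for compound 3 is higher by more than the scatter.

Compound 4 `C/C(=C\c1cccc(-c2ccc(C)cc2)c1)C(N)=O` has not yet been measured. It stands to compound 3 as compound 2 stands to compound 1: methyl in place of hydrogen on an aromatic carbon. The two place descriptions are the same word for word, so this is the same change made on the other core, and among the compounds shown it occurs twice in all.

For the measured compounds named here, the expected step in this assay is a 2.0-fold lower number from compound 3 to compound 4 (0.30 log units; within the scatter), resting on the single measured instance, the step of a 2.0-fold lower number from compound 1 to compound 2 (0.31 log units; beyond the scatter); with only one precedent, and on a different core, the expectation is held loosely. Compound 4 is therefore expected to give about 3300 nM in this assay, with the likely range estimated from 1600 nM to 6600 nM.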

Compound 4, half-maximal inhibitory concentration: 6710 nM
The estimate for compound 4 lay 2.0-fold (0.31 log units) below the measured number; the measured number lies above the stated range.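

On the core of compound 3, methyl in place of hydrogen on an aromatic carbon, para to a large group, gives a step in this assay of a 1.0-fold higher number from compound 3 to compound 4 (0.01 log units; within the scatter), so no effect of the methyl can be read on this core. Set beside the step on the core of compound 1, the two results cannot be separated, since the gap between them does not exceed what two such steps would be expected to show: the same change on two cores in this assay, a 2.0-fold lower number (0.31 log units; beyond the scatter) from compound 1 to compound 2 and a 1.0-fold higher number (0.01 log units; within the scatter) from compound 3 to compound 4, 2.1-fold (0.32 log units) apart, within the scatter of two such steps

This shows that the lower number seen on the core of compound 1 was not repeated on the core of compound 3, but it does not show that the change behaves differently on the two cores, and with only two instances neither transfer nor failure of transfer is established.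

The compounds shown leave open what a group other than methyl, such as an ethyl chain, a methoxy group, an amine or a carboxylic acid, would give at the same place on either core. They also leave open whether the methyl step would be repeated on a third core, and whether a larger group would draw the two cores clearly apart.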